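Fluoro to trifluoromethyl: how large a step to expect

The source may hold more compounds than are shown below. What is called first, only, known or untested is meant among the compounds shown, and "the series" means these compounds.

Three closely related compounds have been tested in an ADME assay on HEK-293T cells (Homo sapiens) for cytotoxicity, read by MTT assay, with a stated time of 24 h (a higher number here means that more compound is tolerated, a lower number that less compound is tolerated), so far. Compound 1 (`COc1ccc(S(=O)(=O)n2c(-c3cn(-c4ccccc4)nc3-c3ccc(C(F)(F)F)cc3)nc3ccccc32)cc1`) gives > 300000 nM as its reading, which is a limit of the assay and not a number. Compound 2 (`O=[N+]([O-])c1ccc(S(=O)(=O)n2c(-c3cn(-c4ccccc4)nc3-c3ccc(C(F)(F)F)cc3)nc3ccccc32)cc1`) gives 163000 nM as a true number, and compound 3 (`O=S(=O)(c1ccc(F)cc1)n1c(-c2cn(-c3ccccc3)nc2-c2ccc(C(F)(F)F)cc2)nc2ccccc21`) gives 157000 nM as another. Compound 3 therefore stands level with compound 2, as a 1.0-fold lower number from compound 2 to compound 3 (0.02 log units; within the scatter) shows.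

Compound 4 (`O=S(=O)(c1ccc(C(F)(F)F)cc1)n1c(-c2cn(-c3ccccc3)nc2-c2ccc(C(F)(F)F)cc2)nc2ccccc21`) differs from compound 3 by a single change (trifluoromethyl in place of fluoro on an aromatic carbon) with trifluoromethyl in place of fluoro on an aromatic carbon, para to a large group.

The nearest guide is the swap of fluoro in place of nitro (a 1.0-fold lower number from compound 2 to compound 3 (0.02 log units; within the scatter)). Among the compounds with values here, it is the only step measured between two true numbers. The two steps that start from the limit are only floors, and both floors lie within the scatter (an at least 1.8-fold lower number from compound 1 to compound 2 (0.26 log units; that floor lies within the scatter) and an at least 1.9-fold lower number from compound 1 to compound 3 (0.28 log units; that floor lies within the scatter)). Within the data shown here, no step from a trifluoromethyl group has been measured yet, so no step beyond the scatter is expected in this assay here. The estimated step is a 1.1-fold lower number from compound 3 to compound 4 (0.05 log units; within the scatter) and no more is expected. For compound 4 the expected value is 140000 nM with an estimated range of 70000 nM to 280000 nM for this reading.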

Compound 4, half-maximal cytotoxic concentration: 63200 nM
For compound 4 the middle estimate is 2.2-fold (0.35 log units) above the measured one; measured number outside the range, below it.
By their numbers in this assay, from the lowest: compound 4; then compounds 3 and 2 (each within the scatter of the next). At a limit, above all of these: compound 1.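

In this assay, this position on the aromatic ring, para to a large group, now proves able to move the reading: trifluoromethyl in place of fluoro gives a 2.5-fold lower number from compound 3 to compound 4 (0.40 log units; beyond the scatter), and trifluoromethyl in place of nitro gives a 2.6-fold lower number from compound 2 to compound 4 (0.41 log units; beyond the scatter), whereas the earlier swap between nitro and fluoro stayed within the scatter. Among the groups shown here, compound 4, with its trifluoromethyl group, therefore sits apart from compounds 2 and 3, and both of its steps join two true numbers. Trifluoromethyl in place of methoxy gives an at least 4.7-fold lower number from compound 1 to compound 4 (0.67 log units; beyond the scatter), the first step from compound 1 to pass the scatter, though it is only a floor, as the reading of compound 1 is a limit and not a number: the limit of > 300000 nM in this assay, at which 1 of the 4 values shown sits.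

The compounds shown leave open how an amine, a carboxylic acid or a nitrile at this same place would read, and whether any of them would fall as low as compound 4 or stay level with compounds 2 and 3. They also leave open whether trifluoromethyl would give a step of similar size at another carbon of this ring or on a different part of the shared core.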